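This account rests on a few compounds, and the source may have more. Where it says the series, first, only, none or still open, it means among the compounds named here.

Working notes, series read in a functional assay on DU-145 cells (Homo sapiens) for cytotoxicity; on this read-out lower numbers stand for stronger inhibition of growth and higher numbers for weaker inhibition of growth:

- compound 1 `COc1ccc(C2=C(c3ccc(SC)cc3)CC3CCCN3C2=O)cc1C`: 900 nM
- compound 2 `CSc1ccc(C2=C(c3ccc(OCC4CO4)cc3)C(=O)N3CCCC3C2)cc1`: 500 nM

Compound 2, at 500 nM, lies within the scatter of compound 1, at 900 nM. Compound 3 `CSc1ccc(C2=C(c3ccc(F)cc3)C(=O)N3CCCC3C2)cc1` has fluoro in place of (oxiran-2-yl)methoxy on an aromatic carbon, para to a large group: fluoro in place of (oxiran-2-yl)methoxy on an aromatic carbon. Among the compounds with values here, no measured pair shows this change, so the expectation is loose. A moderate step towards a higher number in this assay, meaning weaker inhibition of growth, is expected. The expected step is a 2.8-fold higher number from compound 2 to compound 3 (0.45 log units; beyond the scatter). For compound 3 the estimated value is 1400 nM, with an expected range of 350 nM to 5500 nM.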

Compound 3, concentration for 50% growth inhibition: 500 nM
The estimate for compound 3 lay 2.8-fold (0.45 log units) above the measured number; the measured number falls inside the stated range.
By their numbers in this assay, from the lowest: compounds 2, 3 and 1 (each within the scatter of the next).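

In this assay, fluoro in place of (oxiran-2-yl)methoxy on the aromatic carbon, para to a large group, reads as no change at the digits printed from compound 2 to compound 3 (within the scatter), so the three-membered ring is not needed at this position to hold growth inhibition at this level. 4-Fluorophenyl in place of 4-methoxy-3-methylphenyl on the double-bonded ring carbon reads as a 1.8-fold lower number from compound 1 to compound 3 (0.26 log units; within the scatter), so that swap also leaves the read-out within the scatter. No measurement here offers an explanation for either step.

From the compounds shown here alone, whether an amine or a carboxylic acid on this aromatic carbon would hold this level remains open. A longer chain ending in a hydroxyl group is equally untested by the compounds shown.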